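Removing one methoxy group: compound 2 to compound 3

The source may hold more compounds than are shown below. What is called first, only, known or untested is meant among the compounds shown, and "the series" means these compounds.

Measured compounds:
compound 1 `Cn1c(=O)n(Cc2cc(O)c(Cl)cc2Cl)c2ccccc21` — "not determined" (no result reported)
compound 2 `COc1ccc(OC)c(N2CC(c3ccc(F)cc3)OC2=O)c1` — 18 nM

In an assay on cells for inhibition of acyl-CoA (8-3)-desaturase (Homo sapiens), with stated times of 30 min and 3 h (a lower number here means a stronger inhibitor, a higher number a weaker inhibitor), compound 1 `Cn1c(=O)n(Cc2cc(O)c(Cl)cc2Cl)c2ccccc21` is recorded as "not determined" (no result reported), so it adds nothing to the comparison. For the measured compounds named here, compound 2 `COc1ccc(OC)c(N2CC(c3ccc(F)cc3)OC2=O)c1` is therefore the only compound with a number: in this assay compound 2 gives 18 nM, and it stands alone on that scale, with no neighbour to place it above or below.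

Compound 3 `COc1cccc(N2CC(c3ccc(F)cc3)OC2=O)c1` is the next entry, not yet measured. It differs from compound 2 in one place: hydrogen in place of methoxy on an aromatic carbon, ortho to a large group and para to the remaining methoxy group.

Going by the values given here, no step between measured compounds is available to calibrate this change. The working expectation is a small step toward weaker inhibition, at or just beyond the edge of the usual scatter, rather than a large one. The expected step from compound 2 to compound 3 is a 2.2-fold higher number from compound 2 to compound 3 (0.35 log units; beyond the scatter). Compound 3 is estimated at 40 nM, within 10 nM to 160 nM.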

Compound 3, half-maximal inhibitory concentration: 4.1 nM
Beside the measured number, compound 3's estimate is 9.8-fold (0.99 log units) above it; measured number outside the range, below it.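

In this assay, the methoxy group ortho to a large group is not required for inhibition: replacing it with hydrogen gives a 4.4-fold lower number from compound 2 to compound 3 (0.64 log units; beyond the scatter) and marks this step as a real gain rather than scatter. For the compounds shown here, this is the first calibrated change, and it shows that on this aromatic ring, with the rest of the structure held constant, the simpler hydrogen-bearing compound 3 outperforms the dimethoxy compound 2, so the methoxy group at this position contributes no net benefit to the number in this pair. No measurement at hand bears on why the number falls, and the step stands only as an observation.

The compounds shown leave open whether hydrogen is the best substituent at this position or whether a fluorine, a chlorine, a methyl or a hydroxyl group there would match or exceed it. They also leave open how much the remaining methoxy group contributes, and whether a hydrogen, an ethoxy group or a nitrile in its place would move the number in the same direction.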